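The source may report more compounds than this note shows. Statements on the series, on what has been measured and on what is new or still open speak of the compounds shown alone.

Of the compounds shown here, two have so far been tested in a functional assay on HCT-8 cells (Homo sapiens) for cytotoxicity; on this read-out higher numbers stand for an effect only at larger amounts of compound and lower numbers for an effect already at smaller amounts. Compound 1 `CCC1=C(OC)C(CC)(CC)C(=O)C(C(=O)/C=C/c2ccc(CC)cc2)=C1O` gives 8.5 ug/mL, and compound 2 `CCCC1=C(OC)C(CCC)(CCC)C(=O)/C(=C(O)\C=C\c2ccccc2)C1=O` gives 1.4 ug/mL. Compound 2 therefore holds the lower of the two numbers, and the gap lies beyond the usual scatter of repeated measurements. The two compounds differ in more than one place, so this gap cannot be tied to any single change.

The next compound, compound 3 `CCCC1=C(OC)C(CCC)(CCC)C(=O)/C(=C(O)\C=C\c2ccc(Br)cc2)C1=O`, differs from compound 2 in one place only, where phenyl becomes 4-bromophenyl: bromo in place of hydrogen on an aromatic carbon. This puts bromo in place of hydrogen on an aromatic carbon. Going by the values given here, no measured pair isolates such a change. Among the compounds with values here, the only weak hint is compound 1, which also carries a group other than hydrogen on its aromatic ring and gives 8.5 ug/mL, but it differs from compound 2 elsewhere too. The expected step of a 1.4-fold higher number from compound 2 to compound 3 (0.15 log units; within the scatter) is therefore small, with nothing beyond the scatter expected and a slight lean towards a higher number. For compound 3 the estimated value is 2 ug/mL, with an expected range of 0.7 ug/mL to 6 ug/mL.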

Compound 3, concentration for half-maximal effect: 1.3 ug/mL
The estimate for compound 3 lay 1.5-fold (0.19 log units) above the measured number; the measured number falls inside the stated range.
By their numbers in this assay, from the lowest: compounds 3 and 2 (each within the scatter of the next); then compound 1.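

In this assay, putting bromo in place of hydrogen on an aromatic carbon gives a 1.1-fold lower number from compound 2 to compound 3 (0.03 log units; within the scatter), so compound 2 and compound 3 cannot be told apart on this read-out. Going by these compounds alone, this is the first pair of compounds that differ in one place only, and it shows that this carbon of the six-membered aromatic ring, para to a large group, can carry a bromine atom without a change beyond the scatter of repeated measurements. No separate measurement is available to explain this result.

Within the data shown here, a single pair covers only one group at one position, so it remains open whether an amine, a carboxylic acid or a longer chain on the same carbon would also leave the number within the scatter of compound 2. As far as these compounds go, it also remains open whether bromo on another carbon of this ring would behave in the same way, or whether a change elsewhere on the shared core would matter more than this one.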